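The source may report more compounds than this note shows. Statements on the series, on what has been measured and on what is new or still open speak of the compounds shown alone.

Compounds measured in a functional assay on HCT-116 cells (Homo sapiens) for inhibition, read by MTT assay, with a stated time of 48 h; a higher number here means a weaker inhibitor, a lower number a stronger inhibitor:

Compound 1 `CN1CCN(c2ccc(Nc3ncc4c(n3)N(C3CCCC3)CC(=O)N4)nc2)CC1` with > 30000 nM
Compound 2 `O=C1CN(C2CCCC2)c2nc(Nc3ccc(N4CCCCC4)cn3)ncc2N1` with > 30000 nM
Compound 3 `O=C1CN(C2CCCC2)c2nc(Nc3ccc(N4CCNCC4)cn3)ncc2N1` with > 30000 nM

In this assay compound 1 gives only a limit, > 30000 nM, and not a number. Compound 2 likewise sits at a limit, > 30000 nM. Compound 3 also returns a limit, > 30000 nM. Going by the values given here, the three values shown all rest on (the limit of > 30000 nM in this assay, at which 3 of the 3 values shown sit), so no step between them can be read: a step that the two limits leave unreadable from compound 1 to compound 2, a step that the two limits leave unreadable from compound 1 to compound 3 and a step that the two limits leave unreadable from compound 2 to compound 3 are each unreadable.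

Compound 4 `CN1CCN(c2ccc(Nc3ncc4c(n3)N(C3CCCC3)CC(=O)N4C)nc2)CC1` differs from compound 1 in one place: methyl in place of hydrogen on an amide-type nitrogen in a ring. Among the compounds with values here, none of the measured steps touches this position; they move only the group on the aromatic carbon of the pyridine side, and all of them start and end at the limit. There is therefore no measured step that bears directly on the change from compound 1 to compound 4, and no direction can be drawn from the numbers shown.

Given that compound 1 sits at the limit, compound 4 is expected to remain at or near it, with an estimated step of a number no higher from compound 1 to compound 4 (the limit leaves the size open). The estimate for compound 4 in this assay is 30000 nM, in a range from 8000 nM to 100000 nM.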

Compound 4, half-maximal inhibitory concentration: 9730 nM
Beside the measured number, compound 4's estimate is 3.1-fold (0.49 log units) above it; measured number inside the range.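

In this assay the series gives its first readable step, an at least 3.0-fold lower number from compound 1 to compound 4 (0.48 log units; beyond the scatter), and it comes with methyl in place of hydrogen on the amide-type nitrogen in a ring. The entering methyl adds a single carbon and takes away the amide hydrogen, and this one change is enough to bring compound 4 to a real number, so this nitrogen is a place where the read-out responds, which the earlier changes on the aromatic carbon of the pyridine side could not show. Those earlier steps cannot be read, and the step to compound 4 gives only a lower bound on its size, as compound 1 itself stands at a limit: the limit of > 30000 nM in this assay, at which 3 of the 4 values shown sit.

From the compounds shown here alone, whether an ethyl group, a longer chain or a chain ending in a hydroxyl group on this same nitrogen would lower the number further remains open. Going by these compounds, it is equally open whether the methyl would have a similar effect with the piperidin-1-yl group of compound 2 or the piperazin-1-yl group of compound 3 in place of the 4-methylpiperazin-1-yl group.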